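The source may hold more compounds than are shown below. What is called first, only, known or untested is meant among the compounds shown, and "the series" means these compounds.

Measured compounds:
Compound 1 `CC(C)c1cc(-c2n[nH]c(=O)n2-c2cccc(C(=O)NCCCCCC(=O)NO)c2)c(O)cc1O` gives 4600 nM.
Compound 2 `CC(C)c1cc(-c2n[nH]c(=O)n2-c2cccc(NC(=O)CCCCCC(=O)NO)c2)c(O)cc1O` gives 1600 nM.
Compound 3 `CC(C)c1cc(-c2n[nH]c(=O)n2-c2cccc(C(=O)NCCCCCCC(=O)NO)c2)c(O)cc1O` gives 4600 nM.

All three were tested in a functional assay on A549 cells (Homo sapiens) for inhibition; a higher number here means a weaker inhibitor, a lower number a stronger inhibitor. Compound 1 and compound 3 share a core and differ by (hydroxycarbamoyl)methyl in place of hydroxycarbamoyl on a saturated chain carbon, five bonds along the chain from an amide-type nitrogen; that step reads no change at the digits printed from compound 1 to compound 3 (within the scatter). Compound 2 has the same atoms as compound 1 joined differently; the difference between the two cores is not broken down here. Its number is the lowest of the three, and its steps to compound 1 and to compound 3 lie beyond the scatter, so compound 2 is the strongest inhibitor among those measured.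

Compound 4 `CC(C)c1cc(-c2n[nH]c(=O)n2-c2cccc(NC(=O)CCCCCCC(=O)NO)c2)c(O)cc1O` has not yet been measured. It differs from compound 2 by (hydroxycarbamoyl)methyl in place of hydroxycarbamoyl on a saturated chain carbon, five bonds along the chain from a carbonyl carbon, the same kind of change as from compound 1 to compound 3, though here the place is five bonds along the chain from a carbonyl carbon rather than from an amide-type nitrogen. Because the earlier step gave no change at the digits printed from compound 1 to compound 3 (within the scatter), the expected step here is a 1.1-fold higher number from compound 2 to compound 4 (0.05 log units; within the scatter). Compound 4 is thus estimated at 1800 nM in this assay, expected between 800 nM and 4000 nM.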

Compound 4, half-maximal inhibitory concentration: 1600 nM
For compound 4 the middle estimate is 1.1-fold (0.05 log units) above the measured one, within the range that was stated.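

In this assay, putting (hydroxycarbamoyl)methyl in place of hydroxycarbamoyl on the core of compound 2 gave no change at the digits printed from compound 2 to compound 4 (within the scatter). Set beside the earlier step, the change carried from one core to the other without a difference beyond the scatter: the same change on two cores in this assay, no change at the digits printed (within the scatter) from compound 1 to compound 3 and no change at the digits printed (within the scatter) from compound 2 to compound 4, 1.0-fold (0.00 log units) apart, within the scatter of two such steps

This shows agreement on these two cores only, for this single change of chain length; it does not show that the change would leave the number unmoved on any other core, and it gives no cause.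

The compounds shown leave open whether a longer chain, such as 2-(hydroxycarbamoyl)ethyl, would behave the same way. They also leave open what a carboxylic acid in place of the hydroxycarbamoyl end would do in this assay.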